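A few compounds are considered here, and "the series" means these few. Any claim that something is new, unique, unknown or untested is made for them only; others in the source may bear on it.

Compound 2 `Clc1ccc(CO/N=C/c2c(-c3ccc(Br)cc3)nc3sccn23)cc1Cl` gives the lowest of the three numbers measured in an assay on HepG2 cells for agonist activity at nuclear receptor subfamily 1 group I member 3 (Homo sapiens), read by a luciferase reporter, with a stated time of 23 h (a higher number here means that more compound is needed for the effect, a lower number that less compound is needed), at 480 nM. The nearest of the others is compound 3 `C(=N/OC1Cc2ccccc2C1)\c1c(-c2ccc3ccccc3c2)nc2occn12`, which in this assay gives 980 nM, and the furthest is compound 1 `Clc1ccc(CO/N=C/c2c(-c3ccc4ccccc4c3)nc3occn23)cc1`, which gives 990 nM; both of those gaps from compound 2 lie beyond the scatter. Within the data shown here, the one step with a single change among the measured compounds, a 1.0-fold lower number from compound 1 to compound 3 (0.00 log units; within the scatter), concerns the group on the oxygen and lies within the scatter.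

Compound 4 `COc1ccc(-c2nc3sccn3c2/C=N/OCc2ccc(Cl)c(Cl)c2)cc1` differs from compound 2 in one place: methoxy in place of bromo on an aromatic carbon. Among the measured compounds shown here, no measured pair shows this change, and the only single-change step available touches a different part of the molecule, so the data give no direction for it. The number for compound 4 in this assay is therefore expected to stay near that of compound 2, with the step of a 1.3-fold higher number from compound 2 to compound 4 (0.10 log units; within the scatter) estimated to lie within the scatter. Compound 4 is expected to give about 600 nM, within a range from 200 nM to 1800 nM.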

Compound 4, half-maximal effective concentration: 490 nM
Compound 4: middle estimate off by 1.2-fold (0.09 log units), on the high side, within the range that was stated.
By their numbers in this assay, from the lowest: compounds 2, 4, 3 and 1 (each within the scatter of the next, the first and the last beyond it).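

In this assay, among these compounds, replacing the 4-bromophenyl group with 4-methoxyphenyl gives a 1.0-fold higher number from compound 2 to compound 4 (0.01 log units; within the scatter), the first measured single change at this aromatic carbon, since the earlier step concerned only the group on the oxygen. The earlier compounds shown here gave no direction for this change, whereas this pair shows that, with the rest of the molecule held constant, bromo and methoxy cannot be told apart at this position in this assay. Nothing available explains this result or links it to any property of either group.

The compounds shown leave open whether an amine or a carboxylic acid at this position would also stay within the scatter of compound 2. They also leave open whether methoxy in place of bromo would have the same outcome on the core of compound 1.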